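Thiazolyl replaces oxazolidinone in a sulfonamide solubility series

This account rests on a few compounds, and the source may have more. Where it says the series, first, only, none or still open, it means among the compounds named here.

In a physicochemical assay for solubility (on this read-out lower numbers stand for lower solubility and higher numbers for higher solubility), compound 1 `O=C1OCCN1c1cc(C(F)(F)F)ccc1[C@H]1CCOc2cc(S(=O)(=O)Nc3nccs3)ccc21` gives 295000 nM, the smaller of the two numbers recorded, though the gap to compound 2 lies within the scatter. Compound 2 `Cn1nccc1-c1cc(C(F)(F)F)ccc1[C@H]1CCOc2cc(S(=O)(=O)Nc3ncccn3)ccc21` gives 532000 nM in this assay. Compound 3 `O=S(=O)(Nc1nccs1)c1ccc2c(c1)OCC[C@@H]2c1ccc(C(F)(F)F)cc1-c1nccs1` has not yet been measured and differs from compound 1 in one place: 1,3-thiazol-2-yl in place of 2-oxo-1,3-oxazolidin-3-yl on an aromatic carbon. For the measured compounds named here, no step between measured compounds carries this change, so its size is untested. Compound 3 is expected to sit somewhat lower in this assay, with an estimated 100000 nM and a range from 30000 nM to 300000 nM. The expected step of a 3.0-fold lower number from compound 1 to compound 3 (0.47 log units; beyond the scatter) would go beyond the scatter.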

Compound 3, solubility: 15000 nM
Compound 3: the middle estimate sits 6.7-fold (0.82 log units) above what was measured; the measured number lies below the stated range.
By their numbers in this assay, from the lowest: compound 3; then compounds 1 and 2 (each within the scatter of the next).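

In this assay, the position on an aromatic carbon, ortho to a large group and meta to a trifluoromethyl group, proves sensitive: 1,3-thiazol-2-yl in place of 2-oxo-1,3-oxazolidin-3-yl gives a 20-fold lower number from compound 1 to compound 3 (1.29 log units; beyond the scatter). For the compounds shown here, the earlier compounds offered no step at this position, so this is the first size on record for any change there. Nothing measured here explains the size of this step. Going by these compounds, it remains open whether the drop belongs to 1,3-thiazol-2-yl alone or would follow any aromatic ring at this position, and whether an amine or a carboxylic acid there would keep the number closer to that of compound 1.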